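A few compounds are considered here, and "the series" means these few. Any claim that something is new, unique, unknown or untested is made for them only; others in the source may bear on it.

Of the compounds shown here, three have been measured in an ADME assay on J774.A1 cells (Mus musculus) for cytotoxicity, read by MTT assay, with a stated time of 72 h; a higher number here means that more compound is tolerated, a lower number that less compound is tolerated.
Compound 1, `CC1(c2ccc(NC(c3ccc(Br)cc3)c3nnnn3C3CCCCC3)cc2)NC(=O)c2ccccc2N1`: compound 1 gives > 400000 nM.
Compound 2, `Nc1nc(-c2ccc(Cl)cc2)cc(-c2ccc(C3NC(=O)c4ccccc4N3)cc2)n1`: compound 2 gives 82200 nM.
Compound 3, `Nc1nc(-c2ccc(Br)cc2)cc(-c2ccc(C3NC(=O)c4ccccc4N3)cc2)n1`: compound 3 gives 125000 nM.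

The value of compound 1 is a limit of this assay and not a number, (the limit of > 400000 nM in this assay, at which 1 of the 3 values shown sits). Compound 3 and compound 2 share a core and differ in one place: chloro in place of bromo on an aromatic carbon. This change gave a 1.5-fold lower number from compound 3 to compound 2 (0.18 log units; within the scatter). The difference between the core of compound 1 and the core of compound 3 is not broken down here.

Compound 4, `CC1(c2ccc(NC(c3ccc(Cl)cc3)c3nnnn3C3CCCCC3)cc2)NC(=O)c2ccccc2N1`, has not yet been measured in this assay. It stands to compound 1 as compound 2 stands to compound 3: chloro in place of bromo on an aromatic carbon. The two places read the same, so it is the same change. The expected step is a step that the limit leaves unreadable from compound 1 to compound 4, resting on a 1.5-fold lower number from compound 3 to compound 2 (0.18 log units; within the scatter) and on its being within the scatter. Compound 1 sits at the limit (the limit of > 400000 nM in this assay, at which 1 of the 3 values shown sits). Compound 4 is accordingly expected to give 450000 nM, most likely again reported only as a limit, within 200000 nM to 1000000 nM.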

Compound 4, half-maximal cytotoxic concentration: > 400000 nM
Compound 4: a limit, no number (the forecaster's own chance of this, stated with the estimate: 75%); the middle value lies beyond the limit too.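

In this assay, no step from compound 1 to compound 4 can be read, because each of the two values is a limit and not a number: the limit of > 400000 nM in this assay, at which 2 of the 4 values shown sit.

The compounds shown leave open what the change from 4-bromophenyl to 4-chlorophenyl does on the core of compound 1 in numbers.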